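The source may hold more compounds than are shown below. What is called first, only, known or untested is meant among the compounds shown, and "the series" means these compounds.

Measured compounds:
- compound 1, `CCCOC(=O)Nc1ccc([Se]C#N)cc1`, 51900 nM
- compound 2, `CC(C)COC(=O)Nc1ccc([Se]C#N)cc1`, 51200 nM
- compound 3, `CCCCCCOC(=O)Nc1ccc([Se]C#N)cc1`, 48500 nM

All three share one core and differ only in the chain attached through the carbamate oxygen. In a functional assay on HTB-54 cells (Homo sapiens) for cytotoxicity, read by MTT assay, with a stated time of 72 h (on this read-out higher numbers stand for weaker inhibition of growth and lower numbers for stronger inhibition of growth), compound 3 sits within the scatter of its neighbours: a 1.1-fold lower number from compound 1 to compound 3 (0.03 log units; within the scatter) and a 1.1-fold lower number from compound 2 to compound 3 (0.02 log units; within the scatter), and the step of a 1.0-fold lower number from compound 1 to compound 2 (0.01 log units; within the scatter) is likewise flat. Compound 4, `CCOC(=O)Nc1ccc([Se]C#N)cc1`, carries the shortest chain of the set; the change is hydrogen in place of butyl on a saturated chain carbon, two bonds along the chain from an oxygen next to a carbonyl group. The three measured steps all vary this chain and none moves the number beyond the scatter, so no step beyond the scatter is expected here either. Compound 4 is therefore estimated at 50000 nM, with a range of 25000 nM to 100000 nM, meaning an expected step of a 1.0-fold higher number from compound 3 to compound 4 (0.01 log units; within the scatter).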

Compound 4, concentration for total growth inhibition: 49300 nM
For compound 4 the middle estimate is 1.0-fold (0.01 log units) above the measured one; measured number inside the range.
By their numbers in this assay, from the lowest: compounds 3, 4, 2 and 1 (each within the scatter of the next).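

In this assay the shortest chain of the set, the ethyl carbamate of compound 4, stands level with all three longer chains (a 1.0-fold higher number from compound 3 to compound 4 (0.01 log units; within the scatter)) (a 1.0-fold lower number from compound 2 to compound 4 (0.02 log units; within the scatter)) (a 1.1-fold lower number from compound 1 to compound 4 (0.02 log units; within the scatter)). Taking butyl away at this carbon, the largest change in chain length shown, therefore does no more to the number than the smaller changes did. Nothing measured here accounts for this flat picture. The compounds shown leave open whether a chain longer than hexyl would stay within the scatter. They also leave open what an amine or a carboxylic acid on this chain would do.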